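Swapping one halogen for another on the aniline ring

The compounds below may be only part of what the source reports. "The series", "measured", "known", "first", "only" and "open" are said of these compounds alone.

Measured so far:
compound 1, `Clc1ccc(NCc2cn(-c3ccccc3)nc2-c2ccc(Cl)cc2)cc1`, gives 2450 nM;
compound 2, `Cc1ccc(-c2nn(-c3ccccc3)cc2CNc2ccc(Br)cc2)cc1`, gives 6760 nM;
compound 3, `Clc1ccc(NCc2cn(-c3ccccc3)nc2-c2ccc(Br)cc2)cc1`, gives 4290 nM.

All three were tested in a functional assay on B16-F10 cells (Mus musculus) for antiproliferative activity, read by MTT assay, with a stated time of 48 h; a higher number here means a weaker inhibitor, a lower number a stronger inhibitor. Among these three numbers compound 3 stands second highest: its nearest neighbour is compound 2, and its furthest is compound 1, yet both gaps lie within the scatter, so no order among them can be claimed.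

The next compound, compound 4, `Fc1ccc(NCc2cn(-c3ccccc3)nc2-c2ccc(Br)cc2)cc1`, differs from compound 3 in one place only: fluoro in place of chloro on an aromatic carbon.

For the measured compounds named here, only one measured step concerns a halogen swap, and it sits on the other aryl ring: a 1.8-fold higher number from compound 1 to compound 3 (0.24 log units; within the scatter). That step stayed within the scatter. Going by the values given here, for the swap at the aniline ring there is no measured pair at all, so the only guide is that one halogen exchange elsewhere moved the number little.

Compound 4 is therefore expected to land close to compound 3, with a step of a 1.2-fold higher number from compound 3 to compound 4 (0.07 log units; within the scatter) that should not exceed the scatter. The estimate for compound 4 is 5000 nM, within a range from 2000 nM to 12500 nM.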

Compound 4, half-maximal inhibitory concentration: 4180 nM
Compound 4: middle estimate off by 1.2-fold (0.08 log units), on the high side; measured number inside the range.
By their numbers in this assay, from the lowest: compounds 1, 4, 3 and 2 (each within the scatter of the next, the first and the last beyond it).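

For the compounds shown here, compound 4 gives the first measured step at this position on the aniline ring, para to a large group, and fluoro in place of chloro shows a 1.0-fold lower number from compound 3 to compound 4 (0.01 log units; within the scatter) in this assay. Together with the earlier halogen exchange on the other aryl ring, a 1.8-fold higher number from compound 1 to compound 3 (0.24 log units; within the scatter), this means that both halogen swaps shown, at two different places, stay within the scatter. No measurement at hand bears on the reason for this result.

The compounds shown therefore speak only to halogens at this carbon, so what a methoxy group, an amine or a carboxylic acid would do there remains open. Also open, going by these compounds, is whether plain hydrogen at this carbon would give a number close to those of the halogens.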